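The source may hold more compounds than are shown below. What is called first, only, known or untested is meant among the compounds shown, and "the series" means these compounds.

Three compounds sharing the core of compound 1 `O=C1NC(=O)C(Cc2ccc(Oc3ccccc3)cc2)S1` have been measured in a functional assay for agonist activity at Free fatty acid receptor 1 (Homo sapiens), read by FLIPR, in the presence of a further agent that is not named here; on this read-out lower numbers stand for an effect already at smaller amounts and higher numbers for an effect only at larger amounts of compound. Compound 1 gives 307 nM in this assay. Compound 2 `Cc1ccc(Oc2ccc(CC3SC(=O)NC3=O)cc2)cc1` gives 547 nM in this assay, and compound 3 `Cc1ccc(Oc2ccc(CC3SC(=O)NC3=O)cc2)nc1` gives 4470 nM in this assay. Compound 3 stands at the highest number of the three: the step of an 8.2-fold higher number from compound 2 to compound 3 (0.91 log units; beyond the scatter) and the step of a 15-fold higher number from compound 1 to compound 3 (1.16 log units; beyond the scatter) both lie beyond the scatter, whereas the step of a 1.8-fold higher number from compound 1 to compound 2 (0.25 log units; within the scatter) lies within it.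

Compound 4 `O=C1NC(=O)C(Cc2ccc(OCc3ccccc3)cc2)S1` has not yet been measured. It differs from compound 3 by benzyl in place of 5-methylpyridin-2-yl on an oxygen on an aromatic ring. Of the measured steps, the step of a 15-fold higher number from compound 1 to compound 3 (1.16 log units; beyond the scatter) bears most directly on this change, since it also exchanges the group on that oxygen, and the step of an 8.2-fold higher number from compound 2 to compound 3 (0.91 log units; beyond the scatter) points the same way. Both steps ran toward higher numbers when the 5-methylpyridin-2-yl group entered, so its replacement by benzyl is expected to run toward lower numbers in this assay. Within the data shown here, no measured pair shows a benzyl group on that oxygen, so the size of the move remains uncertain. The step of a 7.5-fold lower number from compound 3 to compound 4 (0.87 log units; beyond the scatter) is the expected outcome. Compound 4 is therefore estimated to give 600 nM in this assay, within a range from 150 nM to 2500 nM.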

Compound 4, half-maximal effective concentration: 6180 nM
The estimate for compound 4 lay 10-fold (1.01 log units) below the measured number, outside the stated range (above it).
By their numbers in this assay, from the lowest: compounds 1 and 2 (each within the scatter of the next); then compounds 3 and 4 (each within the scatter of the next).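

In this assay the benzyl group on this oxygen does not bring back the lower numbers lost when the 5-methylpyridin-2-yl group entered, since a 1.4-fold higher number from compound 3 to compound 4 (0.14 log units; within the scatter) lies within the scatter and leaves the two groups indistinguishable here. Set against the groups of the earlier compounds, benzyl stands well apart, with a 20-fold higher number from compound 1 to compound 4 (1.30 log units; beyond the scatter) and an 11-fold higher number from compound 2 to compound 4 (1.05 log units; beyond the scatter) both beyond the scatter, so a ring of carbon only on this oxygen is not enough by itself to match the phenyl of compound 1 or the 4-methylphenyl of compound 2. Nothing at hand explains why benzyl and 5-methylpyridin-2-yl land so close together.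

The compounds shown leave open whether the higher numbers of compound 3 go with the ring nitrogen or the methyl, which a plain pyridin-2-yl group on the same oxygen would help to separate. They also leave open how this position responds to a longer chain such as 2-phenylethyl, or to an amine or a carboxylic acid carried on the terminal ring.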